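Swapping chloro for nitro on the shared core

This account rests on a few compounds, and the source may have more. Where it says the series, first, only, none or still open, it means among the compounds named here.

Measured in a functional assay on HepG2 cells (Homo sapiens) for inhibition, read by MTT assay, with a stated time of 72 h; on this read-out higher numbers stand for weaker inhibition and lower numbers for stronger inhibition:
Compound 1 `COc1cc(O)cc(O)c1C(=O)/C=C/c1ccc(C)cc1`: > 50000 nM, a limit of the assay
Compound 2 `COc1cc(O)cc(O)c1C(=O)/C=C/c1ccc(Cl)cc1`: 12200 nM

Within the data shown here, compound 2 stands at 12200 nM, the only exact number so far. Compound 3 `COc1cc(O)cc(O)c1C(=O)/C=C/c1ccc([N+](=O)[O-])cc1` differs from it by nitro in place of chloro on an aromatic carbon, with nitro in place of chloro on an aromatic carbon, para to a large group. Among the measured compounds shown here, one measured step bears on this aromatic carbon: an at least 4.0-fold lower number from compound 1 to compound 2 (0.61 log units; beyond the scatter), with chloro in place of methyl. That single step does not settle a direction for nitro, so in this assay a small change is expected, a 1.1-fold higher number from compound 2 to compound 3 (0.06 log units; within the scatter). For compound 3 the estimated value is 14000 nM, with an expected range of 5000 nM to 45000 nM.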

Compound 3, half-maximal inhibitory concentration: 41000 nM
The estimate for compound 3 lay 2.9-fold (0.47 log units) below the measured number; the range from low to high includes it.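

In this assay, this aromatic carbon proves to respond to more than the swap of methyl for chloro: nitro in place of chloro gives a 3.4-fold higher number from compound 2 to compound 3 (0.53 log units; beyond the scatter). Compound 2, with chloro, thus stands as the strongest of the three compounds, its steps to both others lying beyond the scatter. Nitro in place of methyl gives an at least 1.2-fold lower number from compound 1 to compound 3 (0.08 log units; that floor lies within the scatter). Compound 1 gives only a limit, so this step is a floor and its true size stays open: the limit of > 50000 nM in this assay, at which 1 of the 3 values shown sits.

The compounds shown leave open how an amine or a carboxylic acid on this aromatic carbon would compare with chloro. They also leave open whether bromo, the nearest relative of chloro, would hold the same level.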